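A few compounds are considered here, and "the series" means these few. Any claim that something is new, unique, unknown or untested is made for them only; others in the source may bear on it.

Three compounds share the same core, a pyridine bearing an azetidinylmethoxy group. Compound 1 `C=Cc1ccc(OC[C@@H]2CCN2)cn1` gives 1.25 nM in an assay on brain for binding affinity to Neuronal acetylcholine receptor; alpha4/beta2 (Rattus norvegicus), read by radioligand binding; a lower number here means a stronger inhibitor, a higher number a weaker inhibitor. Compound 2 `c1ccc(-c2ccc(OC[C@@H]3CCN3)cn2)cc1` gives 2.3 nM in this assay, and the change from compound 1 to compound 2, phenyl in place of vinyl on an aromatic carbon, amounts to a 1.8-fold higher number from compound 1 to compound 2 (0.26 log units; within the scatter). Compound 3 `Clc1cncc(OC[C@@H]2CCN2)c1` gives 0.042 nM in this assay, the lowest of the three numbers; the gap to compound 1 and to compound 2 lies beyond the scatter in each case.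

Compound 4 `CCOc1cncc(OC[C@@H]2CCN2)c1` differs from compound 3 by ethoxy in place of chloro on an aromatic carbon. Among the measured compounds shown here, none of the measured steps concerns this position or this kind of exchange; the only measured step, from compound 1 to compound 2, lies within the scatter and gives no guidance on size or direction here. Given that compound 3 already gives 0.042 nM, the step from compound 3 to compound 4 is expected to be a 3.6-fold higher number from compound 3 to compound 4 (0.55 log units; beyond the scatter), a modest loss. Compound 4 is therefore estimated at 0.15 nM, with a range from 0.03 nM to 0.8 nM.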

Compound 4, inhibition constant: 0.039 nM
Compound 4: middle estimate off by 3.8-fold (0.59 log units), on the high side; the measured number falls inside the stated range.
By their numbers in this assay, from the lowest: compounds 4 and 3 (each within the scatter of the next); then compounds 1 and 2 (each within the scatter of the next).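

In this assay the exchange of chloro for ethoxy on this aromatic carbon, two atoms from the ring nitrogen, gives a 1.1-fold lower number from compound 3 to compound 4 (0.03 log units; within the scatter) and so leaves the two compounds indistinguishable. The position therefore takes 3 heavy atoms, including an oxygen counted as a hydrogen-bond acceptor, in place of a single chlorine without a change beyond the scatter. Nothing available accounts for this result.

Going by these compounds, with only chloro and ethoxy compared at this position, it remains open whether an amine, a carboxylic acid or a longer chain such as butoxy would leave the number equally undisturbed. On these data alone, it also remains open whether chloro or ethoxy would behave alike at the place that carries vinyl in compound 1 and phenyl in compound 2.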